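The source may report more compounds than this note shows. Statements on the series, on what has been measured and on what is new or still open speak of the compounds shown alone.

Compounds measured in an assay on HBE cells for positive allosteric modulation of Cystic fibrosis transmembrane conductance regulator variant F508del (Homo sapiens) (on this read-out higher numbers stand for larger maximal responses and lower numbers for smaller maximal responses), so far:

compound 1, `COc1ccc(Cl)cc1CN[C@H]1[C@H](C(C)(C)C)[C@@H](C(=O)O)N(C(=O)C2CCCCC2)[C@H]1c1ccccc1`, 109%
compound 2, `COc1ccc(C(C)(C)C)cc1CN[C@H]1[C@H](C(C)(C)C)[C@@H](C(=O)O)N(C(=O)C2CCCCC2)[C@H]1c1ccccc1`, 195%

Compound 2 gives the highest of the two numbers in this assay; the nearest is compound 1, and the step of a number 86 percentage points higher from compound 1 to compound 2 (beyond the scatter) lies beyond the scatter.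

Compound 3, `COc1ccc(C(C)(C)C)cc1CN[C@H]1[C@H](C(C)(C)C)[C@@H](C(=O)O)N(C(=O)[C@@H]2CCCCO2)[C@H]1c1ccccc1`, has not been measured. It differs from compound 2 in one place: oxan-2-yl in place of cyclohexyl on a carbonyl carbon

Among the compounds with values here, no measured step bears on this change. Within the data shown here, the only step known, a number 86 percentage points higher from compound 1 to compound 2 (beyond the scatter), concerns the substituent on the aromatic carbon, not the group on the carbonyl carbon, so it gives no guide to the size or direction of the step expected here. With nothing to go on, the expectation for compound 3 is a number near that of compound 2, and the estimated step of a number 25 percentage points lower from compound 2 to compound 3 (beyond the scatter) is taken as small, with a wide range in either direction. For compound 3 the estimate is 170%, between 110% and 230%.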

Compound 3, largest response reached (reported as percent of maximum), in percent of the reference or control that the assay uses: 180%
The estimate for compound 3 lay 10 percentage points below the measured number; the measured number falls inside the stated range.
By their numbers in this assay, from the lowest: compound 1; then compound 3; then compound 2.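

Within the data shown here, changing cyclohexyl to oxan-2-yl on the carbonyl carbon gives the first reading at this position in this assay and shows that the position responds to the swap: a number 15 percentage points lower from compound 2 to compound 3 (beyond the scatter) accompanies the entry of one hydrogen-bond acceptor and one defined stereocentre at an unchanged count of heavy atoms. The earlier pair spoke only to the substituent on the aromatic carbon, where a number 86 percentage points higher from compound 1 to compound 2 (beyond the scatter) is a larger step than the one seen here. Nothing available explains the drop at the carbonyl carbon.

Still open, going by these compounds, is whether the other configuration of the oxan-2-yl group, or the isomeric oxan-4-yl group, would behave in the same way. On these data alone, it is also open how a basic piperidin-4-yl ring or an open methoxyethyl chain would fare here, and whether this step would hold with chloro in place of tert-butyl on the aromatic carbon.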